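From Iodo to Nitro on a Shared Core

This account rests on a few compounds, and the source may have more. Where it says the series, first, only, none or still open, it means among the compounds named here.

Compound 1 `Nc1ncnc2c1c(Br)cn2[C@@H]1C=C(CO)[C@@H](O)[C@H]1O` and compound 2 `Nc1ncnc2c1c(I)cn2[C@@H]1C=C(CO)[C@@H](O)[C@H]1O` share one core and differ in one place, with iodo in place of bromo on an aromatic carbon. In an ADME assay on HepG2 2.2.15 cells (Homo sapiens) for cytotoxicity, read by neutral red uptake, with a stated time of 24 h (on this read-out higher numbers stand for weaker inhibition and lower numbers for stronger inhibition), compound 1 gives > 300000 nM, which is a limit of the assay and not a number. Compound 2 gives > 300000 nM, which is likewise a limit, so it has no exact position on the scale. The whole record so far is the limit of > 300000 nM in this assay, at which 2 of the 2 values shown sit. For the measured compounds named here, the only measured step is a step that the two limits leave unreadable from compound 1 to compound 2, so it supplies no size to carry forward.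

Compound 3 `Nc1ncnc2c1c([N+](=O)[O-])cn2[C@@H]1C=C(CO)[C@@H](O)[C@H]1O` has nitro in place of iodo on an aromatic carbon. Going by the values given here, no measured step covers a nitro group, and the expectation rests only on compound 2 with its limit of > 300000 nM. A change beyond the scatter is not expected in this assay, and a move towards stronger inhibition cannot be ruled out. The estimated change is a number no higher from compound 2 to compound 3 (the limit leaves the size open). For compound 3 the expected value is 300000 nM, with an estimated range from 100000 nM to 500000 nM.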

Compound 3, half-maximal inhibitory concentration: > 300000 nM
Compound 3: no number, only a limit; the forecaster's own chance of this, stated with the estimate: 75%; the middle value sits exactly at the limit.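

Compound 3 joins compound 1 and compound 2 at a limit of the assay and not a number, so the steps among these three compounds cannot be read and no new step comes from this result. The evidence in this assay is confined to one point: the limit of > 300000 nM in this assay, at which 3 of the 3 values shown sit.

What the compounds shown leave open is how far any of compound 1, compound 2 or compound 3 actually lies from that limit, and whether the bromo, iodo and nitro groups differ at all.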